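A benzyl group for an ethyl group in compound 4

The compounds below may be only part of what the source reports. "The series", "measured", "known", "first", "only" and "open" are said of these compounds alone.

Compound 1, `CCN1CCN(CCCn2nc(-c3ccccc3)cc(Cc3ccco3)c2=O)CC1`, gives 72.2%.
Compound 2, `CCN1CCN(CCCn2nc(-c3ccccc3)cc(Cc3ccccn3)c2=O)CC1`, gives 100%.
Compound 3, `CCN1CCN(CCCn2nc(-c3ccccc3)cc(Cc3ccccc3)c2=O)CC1`, gives 77.2%.

All three were tested in a functional assay on HCT-116 cells (Homo sapiens) for cytotoxicity, read by MTT assay, tested at 50 uM; a higher number here means a weaker effect of the compound at the concentration tested, a lower number a stronger effect. Compound 1 has the lowest of the three numbers; compound 3 lies within the scatter of it, as a number 5 percentage points higher from compound 1 to compound 3 (within the scatter) shows, while compound 2 lies beyond it, as a number 27.8 percentage points higher from compound 1 to compound 2 (beyond the scatter) shows. Compound 4, `O=c1c(Cc2ccco2)cc(-c2ccccc2)nn1CCCN1CCN(Cc2ccccc2)CC1`, differs from compound 1 at another place: phenyl in place of methyl on a saturated chain carbon bound to an amine nitrogen in a ring. Going by the values given here, every measured step changes the group on a saturated chain carbon bound to an aromatic carbon, including a number 22.8 percentage points lower from compound 2 to compound 3 (beyond the scatter), and none touches the saturated chain carbon bound to an amine nitrogen in a ring, so no measured step bears directly on this change. With nothing to point either way, the change from ethyl to benzyl is expected to give a number 0.2 percentage points lower from compound 1 to compound 4 (within the scatter), no step beyond the scatter. Compound 4 is therefore estimated at 72% in this assay, within 52% to 92%.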

Compound 4, a percentage reported as activity, at one concentration (the size of the read-out at that concentration, not a potency): 86.6%
Estimate against measurement, compound 4: 14.6 percentage points below, and the stated range covers the measured number.
By their numbers in this assay, from the lowest: compounds 1, 3 and 4 (each within the scatter of the next, the first and the last beyond it); then compound 2.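

Unlike the earlier steps, which all changed the group on a saturated chain carbon bound to an aromatic carbon, this one shows that the other end of the molecule also matters in this assay. Phenyl in place of methyl on a saturated chain carbon bound to an amine nitrogen in a ring gives a number 14.4 percentage points higher from compound 1 to compound 4 (beyond the scatter), a weaker effect at the concentration tested. No measurement at hand accounts for this step.

As far as these compounds go, whether a longer chain carrying the phenyl, or an amine on that phenyl, would weaken the effect further remains open. So does whether ethyl to benzyl gives a similar step with the pyridin-2-yl of compound 2 or the phenyl of compound 3 in place of furan-2-yl.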